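Adding a second fluoro to compound 3

The source may report more compounds than this note shows. Statements on the series, on what has been measured and on what is new or still open speak of the compounds shown alone.

For the measured compounds named here, in a physicochemical assay for solubility, read by HPLC, measured as kinetic solubility, at pH 7 (a higher number here means a more soluble compound, a lower number a less soluble compound), three compounds sharing one core have numbers so far. Compound 1 `FC(F)(F)c1c(CN2CCC(c3ccccc3)CC2)ccn2c(CC3CC3)nnc12` gives 3000 nM, compound 2 `FC(F)(F)c1c(CN2CCCC(c3ccccc3)C2)ccn2c(CC3CC3)nnc12` gives 45000 nM, and compound 3 `Fc1ccccc1C1CCN(Cc2ccn3c(CC4CC4)nnc3c2C(F)(F)F)CC1` gives 2000 nM. Compound 3 thus stands within the scatter of compound 1, while compound 2 holds the highest number of the three, beyond the scatter from compound 3.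

Compound 4 `Fc1ccc(C2CCN(Cc3ccn4c(CC5CC5)nnc4c3C(F)(F)F)CC2)c(F)c1` is one change away from compound 3: fluoro in place of hydrogen on an aromatic carbon. This is fluoro in place of hydrogen on an aromatic carbon, meta to a fluoro group and para to a large group, so that 2-fluorophenyl becomes 2,4-difluorophenyl.

Going by the values given here, only one measured step is of the same kind, a 1.5-fold lower number from compound 1 to compound 3 (0.18 log units; within the scatter), and it lies within the scatter. Compound 2 differs from compound 3 in more than this one replacement, so it offers no direct guide. A single step is thin evidence, and the new fluoro does not repeat the place of the first. With that one small step as the guide, the estimated step is a 1.3-fold lower number from compound 3 to compound 4 (0.10 log units; within the scatter), which means none is expected beyond the scatter. For compound 4 the expected value is 1600 nM, with an estimated range from 700 nM to 3800 nM.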

Compound 4, solubility: < 600 nM
Compound 4 ended at the assay's limit; the forecaster's own chance of this, stated with the estimate: 3%; middle value at least 2.6-fold (0.42 log units) away from the limit.
By their numbers in this assay, from the lowest: compounds 3 and 1 (each within the scatter of the next); then compound 2. At a limit, below all of these: compound 4.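

In this assay, the change from 2-fluorophenyl to 2,4-difluorophenyl gives an at least 3.3-fold lower number from compound 3 to compound 4 (0.52 log units; beyond the scatter), so a fluoro at this position, para to a large group and meta to a fluoro group, moves the read-out beyond the scatter, whereas the earlier fluoro step, a 1.5-fold lower number from compound 1 to compound 3 (0.18 log units; within the scatter), stayed within it. Measured against the plain phenyl, the two fluoro groups together give an at least 5.0-fold lower number from compound 1 to compound 4 (0.69 log units; beyond the scatter), a step that also lies beyond the scatter. The value of compound 4 is a limit of the assay and not a number, so the full size of either step remains unknown: the limit of < 600 nM in this assay, at which 1 of the 4 values shown sits.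

Going by these compounds, whether a fluoro at this same position would have a step of similar size on the phenyl of compound 1, without the 2-fluoro group, remains open. On these data alone, it is also open whether another group in that place, such as a methoxy group, a nitrile or an amine, would shift the read-out in this assay in the same direction or in the opposite one.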